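A few compounds are considered here, and "the series" means these few. Any claim that something is new, unique, unknown or untested is made for them only; others in the source may bear on it.

Compound 1 `O=C(O)c1csc([C@H]2CC[C@@H]3[C@@H](/C=C/COc4ccccc4)[C@H](O)C[C@@H]3O2)n1`: 700 nM
Compound 2 `O=C(O)c1csc([C@H]2CC[C@@H]3[C@@H](/C=C/CCOc4ccccc4)[C@H](O)C[C@@H]3O2)n1`: 160 nM
Compound 3 `O=C(O)c1csc([C@H]2CC[C@@H]3[C@@H](CCCOc4ccccc4)[C@H](O)C[C@@H]3O2)n1`: 4200 nM

These three were measured in a functional assay on CHO cells for agonist activity at prostaglandin E2 receptor EP1 subtype (Homo sapiens), read by fluorescence and calcium flux; a lower number here means that less compound is needed, a higher number that more compound is needed for the effect. Compound 1 differs from compound 2 by phenoxy in place of phenoxymethyl on a saturated chain carbon bound to a double-bonded chain carbon, which gave a 4.4-fold higher number from compound 2 to compound 1 (0.64 log units; beyond the scatter). The difference between the cores of compound 2 and compound 3 is not broken down here; their values simply show compound 3 far higher. Compound 4 `O=C(O)c1csc([C@H]2CC[C@@H]3[C@@H](CCOc4ccccc4)[C@H](O)C[C@@H]3O2)n1` has not yet been measured; it differs from compound 3 by phenoxy in place of phenoxymethyl on a saturated chain carbon, two bonds along the chain from a saturated ring carbon. The place is not identical: in the measured pair the changed carbon is bound to a double-bonded chain carbon, in the new pair it is two bonds along the chain from a saturated ring carbon, so this is the same kind of change, not the same. In this assay compound 4 is expected to show a 3.6-fold higher number from compound 3 to compound 4 (0.55 log units; beyond the scatter), a step of similar size to the earlier one, because of a 4.4-fold higher number from compound 2 to compound 1 (0.64 log units; beyond the scatter). Compound 4 is estimated at 15000 nM, between 4000 nM and 60000 nM.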

Compound 4, half-maximal effective concentration: 97 nM
For compound 4 the middle estimate is 150-fold (2.19 log units) above the measured one; the whole stated range lies above it.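

In this assay the exchange of phenoxymethyl for phenoxy gave a 43-fold lower number from compound 3 to compound 4 (1.64 log units; beyond the scatter), and set against the earlier step, this change did not carry from one core to the other in either direction or size: the same change on two cores in this assay, a 4.4-fold higher number (0.64 log units; beyond the scatter) from compound 2 to compound 1 and a 43-fold lower number (1.64 log units; beyond the scatter) from compound 3 to compound 4, 190-fold (2.28 log units) apart, beyond the scatter of two such steps

The effect of the change therefore depends on its surroundings, and the two pairs differ in whether the chain holds a double bond. For the compounds shown here, with only one pair on each core, they do not show why the direction reverses or what the change would do on any other core.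

As far as these compounds go, it remains open how a longer chain or a chlorine on the phenyl ring would behave on either core. The compounds shown also leave open what an amide in place of the carboxylic acid would do.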